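Benzyl thiourea series: carboxy removal on the aryl ring

A few compounds are considered here, and "the series" means these few. Any claim that something is new, unique, unknown or untested is made for them only; others in the source may bear on it.

Measured compounds:
compound 1, `O=C(O)c1ccc(NC(=S)NCc2ccccc2)cc1O`: 197000 nM
compound 2, `O=C(NNC(=S)NCc1ccccc1)c1ccncc1`: 93200 nM

Of the compounds shown here, two have been measured in a toxicity assay on RAW264.7 cells (Mus musculus) for cytotoxicity, read by MTT assay, with a stated time of 24 h; a lower number here means that less compound is tolerated, a higher number that more compound is tolerated. Compound 1 gives 197000 nM, the highest of the two numbers. Within the data shown here, compound 2 gives 93200 nM, a lower number than compound 1 by a margin beyond the usual scatter; no single-point step connects the two, as they differ in more than one place, so only the two values themselves can be set side by side.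

Compound 3, `Oc1cccc(NC(=S)NCc2ccccc2)c1`, is the next point. Relative to compound 1 the change is hydrogen in place of carboxy on an aromatic carbon, the hydroxy group and the thiourea being kept. Among the measured compounds shown here, no measured pair in the set shows what removing the carboxy does here, so the direction of the step rests on expectation alone. A small step is expected, with a hydrogen in place of the carboxy likely lowering the tolerated concentration somewhat, though a result within the scatter would not surprise. For compound 3 the estimate in this assay is 150000 nM, with a range from 60000 nM to 350000 nM, which would mean an expected step of a 1.3-fold lower number from compound 1 to compound 3 (0.12 log units; within the scatter).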

Compound 3, half-maximal cytotoxic concentration: >= 200000 nM
Compound 3: no number, only a limit; the forecaster's own chance of this, stated with the estimate: 25%; middle value at least 1.3-fold (0.12 log units) away from the limit.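

In this assay compound 3 gives >= 200000 nM, which is a limit of the assay and not a number. Among these compounds, this is the first single-place step, and it reads an at least 1.0-fold higher number from compound 1 to compound 3 (0.00 log units; that floor lies within the scatter), so hydrogen in place of carboxy on this aromatic carbon, ortho to a hydroxy group, brings no drop in the tolerated concentration, and the carboxy is not needed to hold the number at this level in this assay. Only the lower end of the step is fixed, and its actual size cannot be read: the limit of >= 200000 nM in this assay, at which 1 of the 3 values shown sits.

What an amine or a methoxy group would do on this same aromatic carbon stays open, since hydrogen and carboxy are the only two groups shown there. Also open, on these data alone, are how far the true value of compound 3 lies from its limit, and whether the same carboxy removal would read alike on a ring without the hydroxy group.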